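Extending the chain from compound 1: a prediction for compound 3

The source may hold more compounds than are shown below. What is called first, only, known or untested is meant among the compounds shown, and "the series" means these compounds.

Measured so far:
Compound 1, `CCN(CC)CCn1c(N)c(-c2nc3ccccc3[nH]2)c2nc(C#N)c(C#N)nc21`: 1880 nM
Compound 2, `CN(C)CCCn1c(N)c(-c2nc3ccccc3[nH]2)c2nc(C#N)c(C#N)nc21`: 870 nM

In a functional assay on HL-60 cells (Homo sapiens) for antiproliferative activity, read by MTT assay, with a stated time of 48 h (a lower number here means a stronger inhibitor, a higher number a weaker inhibitor), compound 1 gives 1880 nM, the highest of the two numbers; its nearest neighbour is compound 2, which gives 870 nM. Going by the values given here, the one measured step, a 2.2-fold lower number from compound 1 to compound 2 (0.33 log units; beyond the scatter), is modest and lies beyond the scatter. Compound 3, `CCN(CC)CCCn1c(N)c(-c2nc3ccccc3[nH]2)c2nc(C#N)c(C#N)nc21`, has not yet been measured in this assay. It differs from compound 1 in one place: (diethylamino)methyl in place of diethylamino on a saturated chain carbon, two bonds along the chain from an aromatic nitrogen. This change shares with the step from compound 1 to compound 2 the lengthening of the chain by one carbon, while keeping the diethylamino end of compound 1 rather than the dimethylamino end of compound 2. Among the compounds with values here, that single step is the only guide here, and it points toward a somewhat lower number; since the amine itself is unchanged, a smaller shift than a 2.2-fold lower number from compound 1 to compound 2 (0.33 log units; beyond the scatter) is expected, possibly one that stays within the scatter. Compound 3 is therefore estimated at 1200 nM, in a range of 550 nM to 2600 nM, an expected step of a 1.6-fold lower number from compound 1 to compound 3 (0.19 log units; within the scatter).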

Compound 3, half-maximal inhibitory concentration: > 730 nM
Compound 3: no number, only a limit; the forecaster's own chance of this, stated with the estimate: 3%; the middle value does not contradict the limit.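

In this assay compound 3 gives > 730 nM, which is a limit and not a number. Neither the step from compound 1 to compound 3 nor the step from compound 2 to compound 3 can be read. The compounds shown leave open how 3-(diethylamino)propyl compares with 2-(diethylamino)ethyl, and how diethylamino compares with dimethylamino at the end of the same chain, in this assay.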